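Amide aryl swap in a weakly antiproliferative series

A few compounds are considered here, and "the series" means these few. Any claim that something is new, unique, unknown or untested is made for them only; others in the source may bear on it.

Compound 1 `O=C(Nc1ccc(Cl)c(-c2nnc3c(Cl)cccn23)c1)c1ccc(F)cc1Cl` carries a 2-chloro-4-fluorophenyl group on the carbonyl carbon. In a functional assay on MCF7 cells (Homo sapiens) for antiproliferative activity, read by MTT assay, with a stated time of 72 h (on this read-out higher numbers stand for weaker inhibition and lower numbers for stronger inhibition), compound 1 returns > 100000 nM, which is a limit of the assay and not a number. Compound 2 `CS(=O)(=O)c1ccc(C(=O)Nc2ccc(Cl)c(-c3nnc4c(Cl)cccn34)c2)cc1` bears a 4-(methylsulfonyl)phenyl group on the same carbonyl carbon, and in this assay compound 2 gives 94200 nM. Among the measured compounds shown here, the only measured step, an at least 1.0-fold lower number from compound 1 to compound 2 (0.02 log units; that floor lies within the scatter), sits at the floor set by the limit of > 100000 nM in this assay, at which 1 of the 2 values shown sits, and says nothing beyond the scatter. Compound 3 `Cc1cc(Cl)ccc1C(=O)Nc1ccc(Cl)c(-c2nnc3c(Cl)cccn23)c1` is not yet measured; it differs from compound 1 by 4-chloro-2-methylphenyl in place of 2-chloro-4-fluorophenyl on a carbonyl carbon. For the measured compounds named here, no measured step involves a 4-chloro-2-methylphenyl group, so the expectation rests on the two measured compounds both sitting at the weak end of this assay. The step expected for compound 3 is a number no higher from compound 1 to compound 3 (the limit leaves the size open), nothing beyond the scatter. Compound 3 is therefore estimated at 100000 nM, with a range from 40000 nM to 300000 nM, and a limit rather than a number is the more likely outcome.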

Compound 3, half-maximal inhibitory concentration: > 100000 nM
Compound 3: no number, only a limit; the forecaster's own chance of this, stated with the estimate: 65%; the middle value lies on the limit itself.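

In this assay compound 3 gives > 100000 nM, which is a limit of the assay and not a number. The step linking compound 1 to this result cannot be read, and the change from 4-(methylsulfonyl)phenyl to 4-chloro-2-methylphenyl gives an at least 1.0-fold higher number from compound 2 to compound 3 (0.02 log units; that floor lies within the scatter). A third aryl group on the carbonyl carbon therefore adds no readable difference, and no pair of compounds at this position has yet been separated: the limit of > 100000 nM in this assay, at which 2 of the 3 values shown sit.

Whether any group at this position can bring the number clearly under the limit stays open, as the compounds shown carry only substituted phenyl groups there. Also open, as far as these compounds go, is how a phenyl group carrying an amine or a carboxylic acid, or a longer alkyl chain in place of the aryl group, would read in this assay.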